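Chloro in place of hydrogen on the pendant phenyl

This account rests on a few compounds, and the source may have more. Where it says the series, first, only, none or still open, it means among the compounds named here.

Compound 2 `CC1=NN(c2ccccc2)C(=O)C12C=CC(=O)C=C2c1cccc(C)c1` stands at the weak end of the two numbers measured: in a functional assay on MDA-MB-231 cells (Homo sapiens) for antiproliferative activity, read by CCK-8 assay, with a stated time of 72 h (a higher number here means a weaker inhibitor, a lower number a stronger inhibitor), compound 2 gives 85800 nM, while compound 1 `CC1=NN(c2ccc(C)cc2)C(=O)C12C=CC(=O)C=C2c1cccc(C)c1` gives 19400 nM. Among the measured compounds shown here, the only single step seen, a 4.4-fold higher number from compound 1 to compound 2 (0.65 log units; beyond the scatter), is hydrogen in place of methyl on an aromatic carbon. Compound 3 `CC1=NN(c2ccc(Cl)cc2)C(=O)C12C=CC(=O)C=C2c1cccc(C)c1` carries the change (chloro in place of hydrogen on an aromatic carbon), on an aromatic carbon of a six-membered aromatic ring of carbon only, para to a large group. Because occupying that position with methyl gave the lower number of compound 1 19400 nM, compound 3 is expected to move in the same direction, a 4.3-fold lower number from compound 2 to compound 3 (0.63 log units; beyond the scatter). The estimate for compound 3 is 20000 nM, range 7000 nM to 60000 nM.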

Compound 3, half-maximal inhibitory concentration: 26900 nM
Beside the measured number, compound 3's estimate is 1.3-fold (0.13 log units) below it, and the stated range covers the measured number.
By their numbers in this assay, from the lowest: compounds 1 and 3 (each within the scatter of the next); then compound 2.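

In this assay, chloro at this place, para to a large group, gives a lower number than hydrogen, a 3.2-fold lower number from compound 2 to compound 3 (0.50 log units; beyond the scatter), so the earlier methyl step is no longer the only substituent effect seen here. Chloro and methyl are not separated, a 1.4-fold higher number from compound 1 to compound 3 (0.14 log units; within the scatter), and within these compounds both substituents stand apart from hydrogen. Nothing available bears on why this is so.

As far as these compounds go, whether an amine or a carboxylic acid at this place would also give a lower number than hydrogen remains open. So does the effect of a longer chain, such as propyl.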